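A few compounds are considered here, and "the series" means these few. Any claim that something is new, unique, unknown or untested is made for them only; others in the source may bear on it.

In an ADME assay on THP-1 cells (Homo sapiens) for cytotoxicity (on this read-out lower numbers stand for higher toxicity in this test and higher numbers for lower toxicity in this test), the two measured compounds share a core, shown in compound 1 as `Cc1ccc2nc(-c3ccccn3)c(Nc3ccc4c(c3)OCCO4)n2c1` and in compound 2 as `c1ccc(-c2nc3ccccn3c2NC2CCOC2)nc1`. Compound 1 gives 16000 nM in this assay. For compound 2 the assay reports no number, only a limit, > 50000 nM, so compound 2 sits at the limit of this assay the limit of > 50000 nM in this assay, at which 1 of the 2 values shown sits, and its true value is not known. Compound 3, `N#Cc1ccc(Nc2c(-c3ccccn3)nc3ccccn23)cc1`, has not yet been measured in this assay. It differs from compound 2 in one place: 4-cyanophenyl in place of oxolan-3-yl on a nitrogen on an aromatic ring. Among the measured compounds shown here, with only two measured values, one of them a limit, no measured step between them can be counted, so what follows rests only on the shapes of the three compounds. Compound 1 also carries an aromatic ring on the ring nitrogen, and compound 3 follows that pattern rather than the pattern of compound 2, so the step expected from compound 2 to compound 3 in this assay is an at least 2.5-fold lower number from compound 2 to compound 3 (0.39 log units; beyond the scatter), towards higher toxicity and beyond the usual scatter. Compound 3 is therefore estimated at 20000 nM, with a range from 6000 nM to 50000 nM.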

Compound 3, half-maximal cytotoxic concentration: > 50000 nM
Compound 3: a limit, no number (the forecaster's own chance of this, stated with the estimate: 25%); at least 2.5-fold (0.39 log units) between middle value and limit.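

No step from compound 2 to compound 3 can be read in this assay, since each of the two compounds gives only a limit and not a number: the limit of > 50000 nM in this assay, at which 2 of the 3 values shown sit.

The compounds shown leave open what true values lie behind that limit, and so whether 4-cyanophenyl in place of oxolan-3-yl changes the read-out at all.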